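Working notes: from trifluoromethyl to fluoro in the series

The source may report more compounds than this note shows. Statements on the series, on what has been measured and on what is new or still open speak of the compounds shown alone.

Values in an ADME assay on cells (Hepatocyte, Mus musculus) for metabolic stability, with a stated time of 30 min; a higher number here means that more of the compound is left, a lower number that less of the compound is left:
- compound 1 `O=C(OC1CCC(CN2CCN(c3cc(=O)c4cc(C(F)(F)F)cc([N+](=O)[O-])c4s3)CC2)CC1)c1ccccc1`: 68.1%
- compound 2 `O=C(OC1CCC(CN2CCN(c3cc(=O)c4cc(C(F)(F)F)cc([N+](=O)[O-])c4s3)CC2)CC1)c1ccco1`: 0.6%
- compound 3 `O=C(OC1CCC(CN2CCN(c3cc(=O)c4cc(C(F)(F)F)cc([N+](=O)[O-])c4s3)CC2)CC1)c1ccc(C(F)(F)F)cc1`: 28.8%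

Compound 3 holds the middle place of the three, with 28.8%. Compound 4 `O=C(OC1CCC(CN2CCN(c3cc(=O)c4cc(C(F)(F)F)cc([N+](=O)[O-])c4s3)CC2)CC1)c1ccc(F)cc1` differs from it as follows: fluoro in place of trifluoromethyl on an aromatic carbon. In words, this is fluoro in place of trifluoromethyl on an aromatic carbon. The most relevant measurement is the large step that introduced trifluoromethyl, a number 39.3 percentage points lower from compound 1 to compound 3 (beyond the scatter). For the measured compounds named here, compound 4 loses that group, as compound 1 lacks it, but it keeps a substituent in the same place, and no measured compound carries fluoro. The other steps, a number 67.5 percentage points lower from compound 1 to compound 2 (beyond the scatter) and a number 28.2 percentage points higher from compound 2 to compound 3 (beyond the scatter), show that this assay responds widely to changes in the group on the carbonyl carbon. A partial recovery is therefore expected, upward and smaller than the full step back to compound 1. The expected step is a number 16.2 percentage points higher from compound 3 to compound 4 (beyond the scatter). For compound 4 the estimated value is 45%, with an expected range of 22% to 68%.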

Compound 4, percent of the compound remaining: 1.5%
For compound 4 the middle estimate is 43.5 percentage points above the measured one, outside the stated range (below it).
By their numbers in this assay, from the lowest: compounds 2 and 4 (each within the scatter of the next); then compound 3; then compound 1.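

In this assay, the result at this position, para to a large group on the six-membered aromatic ring, does not move in line with the heavy atoms of the substituent: fluoro in place of hydrogen gives a number 66.6 percentage points lower from compound 1 to compound 4 (beyond the scatter), and fluoro in place of trifluoromethyl gives a number 27.3 percentage points lower from compound 3 to compound 4 (beyond the scatter), so the smaller substituent does not recover what trifluoromethyl lost. The 4-fluorophenyl group on the carbonyl carbon also reads level with furan-2-yl, at a number 0.9 percentage points higher from compound 2 to compound 4 (within the scatter), so a six-membered aromatic ring there does not by itself keep the compound in the upper range. Nothing measured here bears on why these steps occur.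

Still open, on these data alone, is how chloro, methoxy or nitrile at this position would read against hydrogen, fluoro and trifluoromethyl. Among the compounds shown, only the unsubstituted phenyl of compound 1 gives the high value, and three compounds cannot show whether any substituent at this position would keep it.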